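The source may report more compounds than this note shows. Statements on the series, on what has been measured and on what is new or still open speak of the compounds shown alone.

Compound 3 `CC(F)(F)c1cccc(N2C(=O)CSC2c2cccc(C(=O)NCCCCc3ccccc3)c2)c1` stands second highest of the three measured compounds in a functional assay on HOS-TE85 cells (Homo sapiens) for inhibition, read by CCK-8 assay, with a stated time of 72 h, tested at 1 uM (on this read-out lower numbers stand for less inhibition and higher numbers for more inhibition at the one concentration tested (going by the name of the read-out)), where compound 3 gives 93%. Compound 1 `COc1cccc(OC)c1N1C(=O)CSC1c1cccc(C(=O)NCCCCc2ccccc2)c1` gives 95% in this assay, and compound 2 `COc1c(F)cccc1N1C(=O)CSC1c1cccc(C(=O)NCCCCc2ccccc2)c1` gives 12%. Exchanging one group for another of the same size on the amide-type nitrogen in the ring, a number 2 percentage points lower from compound 1 to compound 3 (within the scatter), left the number where it was, whereas a number 83 percentage points lower from compound 1 to compound 2 (beyond the scatter) and a number 81 percentage points higher from compound 2 to compound 3 (beyond the scatter) show that a smaller group at that nitrogen can lower the read-out sharply. Compound 4 `O=C(NCCCCc1ccccc1)c1cccc(C2SCC(=O)N2c2ccccc2F)c1` carries a group of 7 heavy atoms (6 carbon, 1 fluorine; one six-membered aromatic ring of carbon only) in place of a group of 10 heavy atoms (8 carbon, 2 fluorine; one six-membered aromatic ring of carbon only), on an amide-type nitrogen in a ring. Among the measured compounds shown here, no measured step mirrors this change, so a drop of uncertain size is expected, a number 38 percentage points lower from compound 3 to compound 4 (beyond the scatter). Compound 4 is therefore estimated at 55%, with a range from 15% to 92%.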

Compound 4, a percentage reported as inhibition, at one concentration (the size of the read-out at that concentration, not a potency): 95%
The estimate for compound 4 lay 40 percentage points below the measured number; measured number outside the range, above it.
By their numbers in this assay, from the lowest: compound 2; then compounds 3, 1 and 4 (each within the scatter of the next).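

With the 2-fluorophenyl group on the amide-type nitrogen in the ring, a number 2 percentage points higher from compound 3 to compound 4 (within the scatter) and no change at the digits printed from compound 1 to compound 4 (within the scatter) show that a group of only 7 heavy atoms holds the read-out at this position. Likewise, a number 83 percentage points higher from compound 2 to compound 4 (beyond the scatter) ties the low number, among these four, to the 3-fluoro-2-methoxyphenyl group and not to a smaller group as such. Nothing given here explains what sets that one group apart. Still open, as far as these compounds go, is how a 2-methoxyphenyl or 3-fluorophenyl group on this nitrogen would read, and whether an aminophenyl or cyclohexyl group would hold the number.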